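The compounds below may be only part of what the source reports. "The series", "measured", "known", "first", "only" and "open" are said of these compounds alone.

Measured in a functional assay on MCF7 cells (Homo sapiens) for antiproliferative activity, read by MTT assay, with a stated time of 72 h (on this read-out lower numbers stand for stronger inhibition and higher numbers for weaker inhibition), so far:

- compound 1 `CCCCCCCCCCCCCCNC[C@@H]1OC[C@H](N)[C@H]1O` gives 8830 nM
- compound 2 `CCCCCCCCCCCCNC[C@@H]1OC[C@H](N)[C@@H]1O` gives 1800 nM
- compound 3 `CCCCCCCCCNC[C@@H]1OC[C@H](N)[C@@H]1O` gives 12500 nM

The values of compound 3 and compound 1 lie within the usual scatter of each other, while compound 2 has a clearly lower number than compound 3. The next structure is compound 4 `CCCCCCCCCCCCCCNC[C@@H]1OC[C@H](N)[C@@H]1O` and the difference is pentyl in place of hydrogen on a saturated chain carbon, nine bonds along the chain from an amine nitrogen.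

Among the compounds with values here, one measured step bears on this place, namely a 6.9-fold higher number from compound 2 to compound 3 (0.84 log units; beyond the scatter), where hydrogen stands in place of propyl. Read in reverse, it shows a lower number when propyl replaces hydrogen, and pentyl is a longer chain than propyl. Within the data shown here, no measured compound shows whether that fall continues beyond propyl, so a similar step in the same direction is the cautious expectation.

The expected change is a 4.2-fold lower number from compound 3 to compound 4 (0.62 log units; beyond the scatter) in this assay, which would be a modest step. For compound 4 the estimate is 3000 nM and the expected range runs from 1000 nM to 9000 nM in this assay.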

Compound 4, half-maximal inhibitory concentration: 720 nM
Compound 4: the middle estimate sits 4.2-fold (0.62 log units) above what was measured, outside the stated range (below it).
By their numbers in this assay, from the lowest: compound 4; then compound 2; then compounds 1 and 3 (each within the scatter of the next).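

In this assay, the fall that comes with lengthening the chain continues past propyl: pentyl gives a 17-fold lower number from compound 3 to compound 4 (1.24 log units; beyond the scatter), and the further ethyl alone still gives a 2.5-fold lower number from compound 2 to compound 4 (0.40 log units; beyond the scatter). Among the three compounds with this drawn configuration, each longer chain therefore gives a lower number, although compound 1, with the same chain as compound 4, shows that chain length alone does not set the value. The gap of a 12-fold lower number from compound 1 to compound 4 (1.09 log units; beyond the scatter) can be assigned to the stereocentre at a saturated ring carbon, drawn the other way, by one fact: the fact that compounds 1 and 4 differ only in the configuration as drawn

As far as these compounds go, it remains open whether a longer chain would lower the number further or reverse the trend. From the compounds shown here alone, it is also open whether an amide in place of the chain's amine nitrogen would keep this activity.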